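Hydroxyphenyl hydrazide series: moving the hydroxyl on the acyl ring

This account rests on a few compounds, and the source may have more. Where it says the series, first, only, none or still open, it means among the compounds named here.

Three compounds have numbers in a physicochemical assay for lipophilicity, read by HPLC, measured as octanol-water partition; a higher number here means a more lipophilic compound, a lower number a more polar compound. Compound 1 `O=C(N/N=C/c1ccc2no[n+]([O-])c2c1)c1cccc(O)c1` gives 1.2. Compound 3 `NC(=O)c1c(COc2ccc(/C=N/NC(=O)c3ccncc3)cc2)no[n+]1[O-]` gives 1.3, and compound 2 `COc1ccc(-c2c(C#N)[n+]([O-])c3cc(C4OCCO4)ccc3[n+]2[O-])cc1` gives 1.4. Compound 1 has the smallest of the three figures, but its gaps to compound 3 and to compound 2 both lie within the scatter of this assay, so the three cannot be told apart on these numbers.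

The next compound, compound 4 `O=C(N/N=C/c1ccc2no[n+]([O-])c2c1)c1ccc(O)cc1`, is a rearrangement of compound 1: 4-hydroxyphenyl in place of 3-hydroxyphenyl on a carbonyl carbon. The same atoms are present, only joined differently. Going by the values given here, no measured pair shows this kind of step, so the expectation rests on the change alone: no step beyond the scatter in either direction.

Compound 4 is expected to give 1.2 in this assay, with a range from 0.9 to 1.5. The estimated step of no change at the digits printed from compound 1 to compound 4 (within the scatter) is therefore expected to sit within the scatter.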

Compound 4, partition coefficient: 1.2
Beside the measured number, compound 4's estimate shows no gap at the digits printed; the measured number falls inside the stated range.
By their numbers in this assay, from the lowest: compounds 1, 4, 3 and 2 (each within the scatter of the next).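

Going by these compounds alone, the pair of compound 1 and compound 4 is the first to differ in one place, and in this assay it reads no change at the digits printed from compound 1 to compound 4 (within the scatter). On this evidence, the two hydroxyphenyl placements on the carbonyl carbon cannot be told apart in this read-out. No further measurement bears on this result, and no explanation can be offered.

Still open, going by these compounds, is whether an amine or a carboxylic acid in place of the hydroxyl would give a step beyond the scatter. This single pair also cannot show whether the result holds on another core.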